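Theophylline-derived esters on MCF7 cells: a naphthyl variant

A few compounds are considered here, and "the series" means these few. Any claim that something is new, unique, unknown or untested is made for them only; others in the source may bear on it.

Measured compounds and values:
- compound 1, `COC(C(=O)OC(C)Cn1cnc2c1c(=O)n(C)c(=O)n2C)c1ccc(C(C)(C)C)cc1`: 82.2%
- compound 2, `Cc1ccc(C(=O)CC(=O)OC(C)Cn2cnc3c2c(=O)n(C)c(=O)n3C)cc1`: 89%
- compound 3, `CC(Cn1cnc2c1c(=O)n(C)c(=O)n2C)OC(=O)Sc1ccccc1`: 86.8%

All three compounds were tested in a functional assay on MCF7 cells (Homo sapiens) for antiproliferative activity, read by MTT assay, with a stated time of 72 h, tested at 25 uM; on this read-out higher numbers stand for a weaker effect at the one concentration tested and lower numbers for a stronger effect. Compound 1 gives 82.2%, the lowest of the three numbers. Its nearest neighbour is compound 3, whose value lies within the scatter of that of compound 1, and compound 2, the furthest, is also within the scatter. On these numbers, then, the three compounds cannot be told apart, and no ordering among them is claimed.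

Compound 4, `COC(C(=O)OC(C)Cn1cnc2c1c(=O)n(C)c(=O)n2C)c1cccc2ccccc12`, is the next variant. It differs from compound 1 as follows:
naphthalen-1-yl in place of 4-(tert-butyl)phenyl on a saturated chain carbon bound to a carbonyl carbon and an oxygen on a saturated carbon

Going by the values given here, no pair of measured compounds differs in a single place, so there is no measured step to lean on. The measured set shows only that three esters of the shared core, carrying quite different aryl-bearing acyl parts, all land close together in this assay . Given that, the expectation for compound 4 is a step of a number 2.2 percentage points lower from compound 1 to compound 4 (within the scatter) that stays within the scatter, in no particular direction. Compound 4 is therefore estimated at 80%, with a range from 65% to 95%.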

Compound 4, a percentage reported as activity, at one concentration (the size of the read-out at that concentration, not a potency): 92.6%
For compound 4 the middle estimate is 12.6 percentage points below the measured one, within the range that was stated.
By their numbers in this assay, from the lowest: compounds 1, 3, 2 and 4 (each within the scatter of the next, the first and the last beyond it).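

In this assay, going by these compounds alone, placing naphthalen-1-yl in place of 4-(tert-butyl)phenyl on the saturated chain carbon bound to a carbonyl carbon and an oxygen on a saturated carbon gives a number 10.4 percentage points higher from compound 1 to compound 4 (beyond the scatter), a modest weakening of the effect and the first single-place step. The read-out therefore responds to a change at this position, even though the heavy-atom count of the group stays the same and a second six-membered aromatic ring enters. No measurement at hand accounts for this step.

Going by these compounds, whether the step follows from the loss of the tert-butyl group or from the added ring stays open, and an unsubstituted phenyl or a naphthalen-2-yl at this carbon would help separate the two. Also open, on these data alone, is how an amine or a carboxylic acid on the aryl group would read here.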